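Furan-3-yl in place of phenyl on the shared core

The compounds below may be only part of what the source reports. "The series", "measured", "known", "first", "only" and "open" are said of these compounds alone.

Compound 2 `Cc1nc(N)c2c(-c3ccccc3)cn([C@@H]3O[C@H](CO)[C@@H](O)[C@H]3O)c2n1` carries a methyl, an amino and a phenyl on the shared core. In a functional assay on HCT-116 cells (Homo sapiens), read by MTT assay, with a stated time of 72 h (a higher number here means a weaker inhibitor, a lower number a stronger inhibitor), compound 2 gives > 20000 nM, which is a limit of the assay and not a number. Compound 3 `Nc1nc(N)c2c(-c3ccccc3)cn([C@@H]3O[C@H](CO)[C@@H](O)[C@H]3O)c2n1` differs from compound 2 by amino in place of methyl on an aromatic carbon. In this assay compound 3 gives > 20000 nM, again a limit. The resulting step that the two limits leave unreadable from compound 2 to compound 3 cannot be read due to the limit of > 20000 nM in this assay, at which 2 of the 3 values shown sit. Among the compounds with values here, compound 1 `Cc1ncnc2c1c(I)cn2[C@@H]1O[C@H](CO)[C@@H](O)[C@H]1O` is the only member with a number: in this assay compound 1 gives 7570 nM.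

Compound 4 `Cc1nc(N)c2c(-c3ccoc3)cn([C@@H]3O[C@H](CO)[C@@H](O)[C@H]3O)c2n1` is not yet measured. It differs from compound 2 by furan-3-yl in place of phenyl on an aromatic carbon. Within the data shown here, no measured step covers this change; the single measured step, a step that the two limits leave unreadable from compound 2 to compound 3, is unreadable and concerns another position. Compound 2 stands at the limit, so nothing shows how far past it the true value lies, and nothing shows whether the change toward compound 4 helps or hurts. Compound 4 is therefore expected to sit near the limit as well, the step that the limit leaves unreadable from compound 2 to compound 4 being an expectation of no change beyond the scatter. The estimate for compound 4 in this assay is 25000 nM, expected to fall between 8000 nM and 80000 nM.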

Compound 4, half-maximal inhibitory concentration: > 20000 nM
Compound 4: a limit, no number; the forecaster's own chance of this, stated with the estimate: 70%; the middle value is on the limit's open side.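

In this assay compound 4 gives > 20000 nM, a limit of the assay and not a number. The step from compound 2 to compound 4 therefore cannot be read, for one reason: the limit of > 20000 nM in this assay, at which 3 of the 4 values shown sit. The compounds shown leave open how far past the limit compound 2, compound 3 and compound 4 truly lie, and whether furan-3-yl in place of phenyl changes anything.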